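Changing the aryl group on an inactive compound

This account rests on a few compounds, and the source may have more. Where it says the series, first, only, none or still open, it means among the compounds named here.

In a functional assay on HeLa cells (Homo sapiens) for antiproliferative activity, read by MTT assay, with a stated time of 72 h (on this read-out higher numbers stand for weaker inhibition and lower numbers for stronger inhibition), compound 3 `COc1ccccc1-c1ncnn1-c1cc(OC)c(OC)c(OC)c1` gives > 10000 nM, which is a limit and not a number. Compound 2 `COc1cc(-n2ncnc2-c2cccc(Cl)c2)cc(OC)c1OC` also stands at a limit, > 10000 nM. Compound 1 `COc1ccc(-c2ncnn2-c2cc(OC)c(OC)c(OC)c2)cc1` gives a true number, 280 nM. Compound 4 `COc1cc(-n2ncnc2-c2ccc(SC)cc2)cc(OC)c1OC` has 4-(methylsulfanyl)phenyl in place of 2-methoxyphenyl (4-(methylsulfanyl)phenyl in place of 2-methoxyphenyl on an aromatic carbon). Two large measured steps bear on this: 2-methoxyphenyl replacing 4-methoxyphenyl gave an at least 35-fold higher number from compound 1 to compound 3 (1.55 log units; beyond the scatter), and 3-chlorophenyl replacing it gave an at least 35-fold higher number from compound 1 to compound 2 (1.55 log units; beyond the scatter). Compound 4 carries 4-(methylsulfanyl)phenyl on the same aromatic carbon where compound 1 carries 4-methoxyphenyl. A large step toward a lower number is therefore expected, an at least 25-fold lower number from compound 3 to compound 4 (1.39 log units; beyond the scatter). For compound 4 the estimated value is 400 nM, with an expected range from 60 nM to 4000 nM.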

Compound 4, half-maximal inhibitory concentration: 150 nM
Compound 4: the middle estimate sits 2.7-fold (0.43 log units) above what was measured, within the range that was stated.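

Methylsulfanyl in place of methoxy gives a 1.9-fold lower number from compound 1 to compound 4 (0.27 log units; within the scatter), so on this read-out the two groups cannot be told apart, and activity on this aromatic carbon does not rest on 4-methoxyphenyl alone. Against the two inactive aryl groups, 4-(methylsulfanyl)phenyl gives an at least 66-fold lower number from compound 3 to compound 4 (1.82 log units; beyond the scatter) and an at least 66-fold lower number from compound 2 to compound 4 (1.82 log units; beyond the scatter). Both of these steps start from a limit and not from a number: the limit of > 10000 nM in this assay, at which 2 of the 4 values shown sit.

The compounds shown leave open how a 4-aminophenyl or a 4-ethoxyphenyl group would behave on this same carbon.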